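The source may hold more compounds than are shown below. What is called first, only, known or untested is meant among the compounds shown, and "the series" means these compounds.

Notes on the series. Among the measured compounds shown here, compound 1 `C=CCc1ccc(OCc2cn(-c3ccc(C#N)cc3)nn2)c(O)c1` gives 35.7% in a functional assay on MCF7 cells (Homo sapiens) for inhibition, read by MTT assay, with a stated time of 72 h, tested at 30 uM (on this read-out lower numbers stand for less inhibition of growth and higher numbers for more inhibition of growth at the one concentration tested), and stands highest of the three numbers measured so far, though its nearest neighbour compound 2 `C=CCc1ccc(OCc2cn(-c3ccccc3CO)nn2)c(O)c1`, with 34.5% in this assay, and its furthest neighbour compound 3 `C=CCc1ccc(OCc2cn(-c3cccc(C#N)c3)nn2)c(O)c1`, with 31.9%, both lie within the scatter of it. Every step recorded so far exchanges the aryl group on the aromatic nitrogen of the shared core: a number 1.2 percentage points lower from compound 1 to compound 2 (within the scatter), a number 3.8 percentage points lower from compound 1 to compound 3 (within the scatter) and a number 2.6 percentage points lower from compound 2 to compound 3 (within the scatter), none of them beyond the scatter.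

Compound 4 `C=CCc1ccc(OCc2cn(-c3ccc(C(=O)c4ccccc4)cc3)nn2)c(O)c1` remains to be measured. It differs from compound 1 in one place: benzoyl in place of cyano on an aromatic carbon. The measured steps bear on it only loosely, since each of them swaps the whole aryl group on the aromatic nitrogen, whereas here the substituent on that ring is exchanged, a change of a different kind from anything measured; still, all three exchanges seen so far left this assay within the scatter. No step beyond the scatter is therefore expected in this assay, and the expected step is a number 0.7 percentage points lower from compound 1 to compound 4 (within the scatter). For compound 4 the estimate in this assay is 35%, with a range from 20% to 52%.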

Compound 4, percent growth inhibition at one concentration: 40.3%
Estimate against measurement, compound 4: 5.3 percentage points below; measured number inside the range.
By their numbers in this assay, from the lowest: compounds 3, 2, 1 and 4 (each within the scatter of the next).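

Among the compounds shown here, this is the first exchange on the aromatic carbon that is para to a large group, rather than of the whole aryl group on the aromatic nitrogen, and in this assay benzoyl in place of cyano gives a number 4.6 percentage points higher from compound 1 to compound 4 (within the scatter). The step stays within the scatter even though cyano, with 2 heavy atoms and no ring, gives way to benzoyl, with 8 heavy atoms and one six-membered aromatic ring, so at this position the size of the group entering and the added ring come with no step beyond the scatter in this one pair. No measurement on hand offers an account of how this exchange acts on the number.

The compounds shown leave open whether an amine, a carboxylic acid or a longer chain on this same aromatic carbon would give a step beyond the scatter in this assay. On these data alone, all four numbers also rest on a single tested concentration, so how these compounds compare across a range of concentrations remains open.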